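The source may report more compounds than this note shows. Statements on the series, on what has been measured and on what is new or still open speak of the compounds shown alone.

Compound 3, `CC1(C)Cc2c(sc(NC(=O)C3(CO)CC3)c2C(N)=O)C(C)(C)O1`, stands second highest of the three numbers measured in an assay on cells for positive allosteric modulation of Cystic fibrosis transmembrane conductance regulator variant F508del (Homo sapiens), with stated times of 10 min and 7 s, in the presence of a further agent that is not named here (on this read-out higher numbers stand for an effect only at larger amounts of compound and lower numbers for an effect already at smaller amounts), where compound 3 gives 15 nM. Its nearest neighbour is compound 1, `CC1(C)Cc2c(sc(NC(=O)c3ccccc3O)c2C(N)=O)C(C)(C)O1`, which in this assay gives 4 nM; the furthest is compound 2, `CC1(C)Cc2c(sc(NC(=O)c3nnc[nH]3)c2C(N)=O)C(C)(C)O1`, which gives 467 nM. All three measured steps lie beyond the scatter: a 120-fold higher number from compound 1 to compound 2 (2.07 log units; beyond the scatter), a 3.8-fold higher number from compound 1 to compound 3 (0.57 log units; beyond the scatter) and a 31-fold lower number from compound 2 to compound 3 (1.49 log units; beyond the scatter).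

Compound 4, `CC(C)(C)CC(O)C(=O)Nc1sc2c(c1C(N)=O)CC(C)(C)OC2(C)C`, is not yet measured. It differs from compound 3 in one place: a group of 7 heavy atoms (6 carbon, 1 oxygen; no ring) in place of a group of 5 heavy atoms (4 carbon, 1 oxygen; one three-membered non-aromatic ring of carbon only), on a carbonyl carbon. Within the data shown here, no measured step exchanges one open-chain group for another on that carbonyl carbon, so the bearing of the earlier steps is indirect. The step of a 120-fold higher number from compound 1 to compound 2 (2.07 log units; beyond the scatter) shows that the group on the carbonyl carbon can shift the number greatly, whereas a 3.8-fold higher number from compound 1 to compound 3 (0.57 log units; beyond the scatter) shows that a small group carrying a hydroxyl keeps the number close to that of compound 1. A modest step is expected for compound 4, a 1.7-fold higher number from compound 3 to compound 4 (0.22 log units; within the scatter), with the direction uncertain and a slight lean towards a higher number, because a 3.8-fold higher number from compound 1 to compound 3 (0.57 log units; beyond the scatter) is itself modest and the entering group, like the leaving one, carries a hydroxyl and no aromatic ring. For compound 4 in this assay the estimate is 25 nM, within a range from 6 nM to 120 nM.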

Compound 4, half-maximal effective concentration: 0.54 nM
Compound 4: middle estimate off by 46-fold (1.67 log units), on the high side, outside the stated range (below it).
By their numbers in this assay, from the lowest: compound 4; then compound 1; then compound 3; then compound 2.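

In this assay, among these compounds, the step of a 28-fold lower number from compound 3 to compound 4 (1.44 log units; beyond the scatter) shows that the group on this carbonyl carbon can move the number greatly even when the hydrogen-bond donor and acceptor counts of the leaving and entering groups are the same, which no earlier step could show, as each of those also changed the ring. Compound 4 also takes the lowest number of the four, and the step of a 7.4-fold lower number from compound 1 to compound 4 (0.87 log units; beyond the scatter) shows that an aromatic ring in this place is not needed for a low number, as the open-chain group and the 2-hydroxyphenyl group have the same count of heavy atoms, while the step of an 860-fold lower number from compound 2 to compound 4 (2.94 log units; beyond the scatter) widens the known span at this position. No measurement at hand offers an explanation for these steps.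

The compounds shown leave open whether the hydroxyl of the entering group is needed, and whether an amine in its place or a longer chain would keep the number this low. They also do not separate the loss of the three-membered ring from the gain in heavy atoms, as the two change together from compound 3 to compound 4.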